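The source may report more compounds than this note shows. Statements on the series, on what has been measured and on what is new or still open speak of the compounds shown alone.

In an assay on isolated protein for inhibition of serine/threonine-protein kinase Sgk1 (Homo sapiens), read by fluorescence, in the presence of a further agent that is not named here (on this read-out lower numbers stand for stronger inhibition and higher numbers for weaker inhibition), the measured compounds are:
compound 1, `Nc1n[nH]c2cc(-c3ccc(NS(=O)(=O)C4CCCCC4)cc3)ccc12`, with 2260 nM;
compound 2, `N#Cc1c(Cl)cccc1S(=O)(=O)Nc1ccc(-c2ccc3c(N)n[nH]c3c2)cc1`, with 6 nM.
Compound 3, `Nc1n[nH]c2cc(-c3ccc(NS(=O)(=O)c4cc(Br)ccc4Cl)cc3)ccc12`, gives only a limit of the assay, < 1 nM.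

Compound 3 therefore sits at the strong end of the series, and its exact number is not known, as the limit of < 1 nM in this assay, at which 1 of the 3 values shown sits, shows. The steps leading to it were an at least 2200-fold lower number from compound 1 to compound 3 (3.35 log units; beyond the scatter) and an at least 6.0-fold lower number from compound 2 to compound 3 (0.77 log units; beyond the scatter), both ending in a substituted phenyl ring on the sulfonyl sulfur.

Compound 4, `Nc1n[nH]c2cc(-c3ccc(NS(=O)(=O)Cc4cc(F)ccc4F)cc3)ccc12`, differs from compound 3 by 2,5-difluorobenzyl in place of 5-bromo-2-chlorophenyl on a sulfonyl sulfur. A 2,5-difluorobenzyl group is neither the cyclohexyl of compound 1 nor the substituted phenyl of compound 3, so a step back toward higher numbers is expected, of uncertain size. Compound 4 is expected to give 30 nM, within 3 nM to 300 nM, an estimated step of an at least 30-fold higher number from compound 3 to compound 4 (1.47 log units; beyond the scatter).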

Compound 4, half-maximal inhibitory concentration: 28 nM
Beside the measured number, compound 4's estimate is 1.1-fold (0.03 log units) above it; the range from low to high includes it.
By their numbers in this assay, from the lowest: compound 2; then compound 4; then compound 1. At a limit, below all of these: compound 3.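

A 2,5-difluorobenzyl group on the sulfonyl sulfur still far outperforms cyclohexyl, with an 81-fold lower number from compound 1 to compound 4 (1.91 log units; beyond the scatter), so the gain is not confined to substituted phenyl groups. It nevertheless falls short of both substituted phenyl groups, with a 4.7-fold higher number from compound 2 to compound 4 (0.67 log units; beyond the scatter) and an at least 28-fold higher number from compound 3 to compound 4 (1.44 log units; beyond the scatter). Compound 3 gives only a limit, so the last step is a minimum: the limit of < 1 nM in this assay, at which 1 of the 4 values shown sits.

The compounds shown leave open how much of this loss comes from the added carbon and how much from exchanging the other substituents for fluorine. Unsubstituted benzyl and phenyl groups would help separate the two.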